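Replacing the substituted phenyl group of compound 3

A few compounds are considered here, and "the series" means these few. Any claim that something is new, unique, unknown or untested is made for them only; others in the source may bear on it.

- Compound 1 `O=C1/C(=C\c2ccc(O)cc2)S/C(=N/c2ccccc2)N1Cc1ccncc1` gives 142000 nM
- Compound 2 `O=C1/C(=C\c2ccc([N+](=O)[O-])cc2)S/C(=N/c2ccccc2)N1Cc1ccncc1` gives 250000 nM
- Compound 3 `COc1cc(/C=C2/S/C(=N/c3ccccc3)N(Cc3ccncc3)C2=O)ccc1O` gives 67400 nM

In an ADME assay on HEK293 cells (Homo sapiens) for cytotoxicity, read by MTT assay, with a stated time of 48 h (on this read-out higher numbers stand for weaker inhibition and lower numbers for stronger inhibition), compound 3 gives 67400 nM and stands lowest of the three. Compound 4 `COc1ccc(OC)c(/C=C2/S/C(=N/c3ccccc3)N(Cc3ccncc3)C2=O)c1` differs from it on a double-bonded chain carbon bound to a double-bonded ring carbon, where 2,5-dimethoxyphenyl enters in place of 4-hydroxy-3-methoxyphenyl (2,5-dimethoxyphenyl in place of 4-hydroxy-3-methoxyphenyl on a double-bonded chain carbon bound to a double-bonded ring carbon). All three measured steps change the group at that place: a 1.8-fold higher number from compound 1 to compound 2 (0.25 log units; within the scatter) stays within the scatter while a 2.1-fold lower number from compound 1 to compound 3 (0.32 log units; beyond the scatter) and a 3.7-fold lower number from compound 2 to compound 3 (0.57 log units; beyond the scatter) are modest. Within the data shown here, no measured compound carries the entering group, so no step beyond the scatter is expected, and the estimated change is a 1.5-fold higher number from compound 3 to compound 4 (0.17 log units; within the scatter) in size. For compound 4 the estimate is 100000 nM with an expected range from 40000 nM to 240000 nM in this read-out.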

Compound 4, half-maximal inhibitory concentration: 80100 nM
Beside the measured number, compound 4's estimate is 1.2-fold (0.10 log units) above it, within the range that was stated.
By their numbers in this assay, from the lowest: compounds 3, 4, 1 and 2 (each within the scatter of the next, the first and the last beyond it).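

In this assay, the entering 2,5-dimethoxyphenyl carries no hydrogen-bond donor, yet a 1.2-fold higher number from compound 3 to compound 4 (0.07 log units; within the scatter) stays within the scatter, so a donor on the group at this place is not required for a number in this range. Likewise, a 1.8-fold lower number from compound 1 to compound 4 (0.25 log units; within the scatter) stays within the scatter, whereas a 3.1-fold lower number from compound 2 to compound 4 (0.49 log units; beyond the scatter) goes beyond it, leaving the 4-nitrophenyl compound apart from compound 4. No available evidence bears on why these steps have these sizes. The compounds shown leave open whether an amine or a carboxylic acid on the phenyl group at this place would shift the number beyond the scatter.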